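The compounds below may be only part of what the source reports. "The series", "measured", "known", "first", "only" and "open" are said of these compounds alone.

Of the compounds shown here, two with the same core have been measured in a functional assay on HeLa cells (Homo sapiens) for antiproliferative activity, read by MTT assay, with a stated time of 48 h; a lower number here means a stronger inhibitor of growth, a higher number a weaker inhibitor of growth. Compound 1 `CCOC(=O)c1sc2ccc(NCc3nc[nH]c3C)cc2c1NC(=O)c1ccc(OC)cc1` gives 8220 nM in this assay. Among the compounds with values here, compound 2 `CCOC(=O)c1sc2ccc(NCc3nc[nH]c3C)cc2c1NC(=O)c1ccc(C)cc1` gives 11400 nM in this assay, the higher of the two numbers, though the single step of a 1.4-fold higher number from compound 1 to compound 2 (0.14 log units; within the scatter) shows that the two lie within the scatter of each other, so neither can be called the stronger inhibitor.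

Compound 3 `CCOC(=O)c1sc2ccc(NCc3nc[nH]c3C)cc2c1NC(=O)c1cc(OC)c(OC)c(OC)c1` has not yet been measured. It differs from compound 2 in one place: 3,4,5-trimethoxyphenyl in place of 4-methylphenyl on a carbonyl carbon. Within the data shown here, the only measured step that bears on this change is the swap of one aromatic substituent for another, a 1.4-fold higher number from compound 1 to compound 2 (0.14 log units; within the scatter), which stayed within the scatter. On that basis a step of about a 1.6-fold lower number from compound 2 to compound 3 (0.21 log units; within the scatter) from compound 2 to compound 3 is expected, with no clear direction beyond the scatter. For compound 3 the estimate in this assay is therefore 7000 nM, within a range from 2000 nM to 25000 nM.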

Compound 3, concentration for 50% growth inhibition: 2230 nM
Estimate against measurement, compound 3: 3.1-fold (0.50 log units) above; low and high end bracket the measured number.
By their numbers in this assay, from the lowest: compound 3; then compounds 1 and 2 (each within the scatter of the next).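

Placing 3,4,5-trimethoxyphenyl on the carbonyl carbon gives the first change in this set that moves the number beyond the scatter, with a 5.1-fold lower number from compound 2 to compound 3 (0.71 log units; beyond the scatter) and a 3.7-fold lower number from compound 1 to compound 3 (0.57 log units; beyond the scatter) in this assay. Compound 3 is therefore the strongest inhibitor of growth of the three, while 4-methylphenyl and 4-methoxyphenyl at this place cannot be told apart. The aromatic group on this carbonyl carbon can thus shift the result, although nothing available explains the gain in activity.

The compounds shown leave open whether all three methoxy groups are needed for this gain, or whether one or two would give the same result. On these data alone, it also remains open how a phenyl ring carrying an amine or a carboxylic acid would behave at this place.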